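Chloro in Place of Hydrogen on Two Oxazolidinone Scaffolds

The source may hold more compounds than are shown below. What is called first, only, known or untested is meant among the compounds shown, and "the series" means these compounds.

Compound 2 `O=C(CCCCCc1ccc(O)cc1)N1CCOC1=O` and compound 1 `O=C(CCCCCc1ccc(O)c(Cl)c1)N1CCOC1=O` share one core, while compound 3 `O=C1OCCN1C(=O)c1ccc(Oc2ccccc2)cc1` carries another; the difference between the two cores is not broken down here. In an assay on HEK293 cells for inhibition of N-acylethanolamine-hydrolyzing acid amidase (Rattus norvegicus), read by LC-MS, with a stated time of 30 min (on this read-out lower numbers stand for stronger inhibition and higher numbers for weaker inhibition), compound 2 gives 61 nM. Compound 1 reaches only a limit of this assay, > 20000 nM. The step of an at least 320-fold higher number from compound 2 to compound 1 (2.51 log units; beyond the scatter) follows (chloro in place of hydrogen on an aromatic carbon), and the value of compound 1 sits at the limit of > 20000 nM in this assay, at which 1 of the 3 values shown sits. In this assay compound 3 gives 680 nM. Compound 4 `O=C1OCCN1C(=O)c1ccc(Oc2cccc(Cl)c2)cc1` is not yet measured; it differs from compound 3 by chloro in place of hydrogen on an aromatic carbon. This is the same kind of change, but here the chloro is meta to a large group only, not also ortho to a hydroxy group. Resting on an at least 320-fold higher number from compound 2 to compound 1 (2.51 log units; beyond the scatter) while the surroundings differ, compound 4 is expected to give 1500 nM, between 300 nM and 10000 nM. The expected step of a 2.2-fold higher number from compound 3 to compound 4 (0.34 log units; beyond the scatter) is thus estimated smaller than the earlier one.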

Compound 4, half-maximal inhibitory concentration: 7740 nM
Beside the measured number, compound 4's estimate is 5.2-fold (0.71 log units) below it, and the stated range covers the measured number.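

In this assay the change brings an 11-fold higher number from compound 3 to compound 4 (1.06 log units; beyond the scatter) and so runs the same way on both cores, but its size does not carry over from one core to the other: the same change on two cores in this assay, an at least 320-fold higher number (2.51 log units; beyond the scatter) from compound 2 to compound 1 and an 11-fold higher number (1.06 log units; beyond the scatter) from compound 3 to compound 4, at least 28-fold (1.45 log units) apart, beyond the scatter of two such steps. With a single pair on each core, this does not show what sets the two steps apart, nor how the change would read on any further core. Compound 1 stands at a limit: the limit of > 20000 nM in this assay, at which 1 of the 4 values shown sits.

The compounds shown leave open whether fluoro or methoxy in place of the same hydrogen would follow chloro on either core. They also leave open whether compound 1 would keep its step if its hydroxy group were replaced by methoxy.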